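The source may report more compounds than this note shows. Statements on the series, on what has been measured and on what is new or still open speak of the compounds shown alone.

Measured compounds:
- Compound 1 `CN(C)CCn1cnnc1-c1cc(Oc2ccc(NC(=O)N/N=C/c3c[nH]c4ccccc34)cc2F)ccn1`: 1630 nM
- Compound 2 `Cn1cnnc1-c1cc(Oc2ccc(NC(=O)N/N=C/c3ccccc3)cc2F)ccn1`: 15700 nM
- Compound 3 `COc1cc(/C=N/NC(=O)Nc2ccc(Oc3ccnc(-c4nncn4CCN(C)C)c3)c(F)c2)ccc1O`: 57 nM

In a functional assay on NCI-H460 cells (Homo sapiens) for cytotoxicity, read by MTT assay, with a stated time of 72 h (a lower number here means a stronger inhibitor, a higher number a weaker inhibitor), compound 1 gives 1630 nM, the second highest of the three numbers. Its nearest neighbour is compound 2 at 15700 nM, and the furthest is compound 3 at 57 nM. The step from compound 1 to compound 3 replaces the 1H-indol-3-yl group with a 4-hydroxy-3-methoxyphenyl group and gives a 29-fold lower number from compound 1 to compound 3 (1.46 log units; beyond the scatter), a large drop in the number well beyond the scatter.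

Compound 4 `CN(C)CCn1cnnc1-c1cc(Oc2ccc(NC(=O)N/N=C/c3ccc(O)cc3O)cc2F)ccn1` is not yet measured. It differs from compound 1 in one place: 2,4-dihydroxyphenyl in place of 1H-indol-3-yl on a carbon with a double bond to nitrogen. For the measured compounds named here, this change resembles the one from compound 1 to compound 3, since both put a hydroxy-bearing phenyl ring where the indolyl group sat, so a step of similar direction is expected, though the two hydroxy groups instead of one hydroxy and one methoxy leave some uncertainty. A clear drop in the number is therefore expected, estimated at an 11-fold lower number from compound 1 to compound 4 (1.04 log units; beyond the scatter). For compound 4 the estimate in this assay is 150 nM, within a range from 40 nM to 600 nM.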

Compound 4, half-maximal inhibitory concentration: 11300 nM
For compound 4 the middle estimate is 75-fold (1.88 log units) below the measured one, and the stated range ends below it.
By their numbers in this assay, from the lowest: compound 3; then compound 1; then compounds 4 and 2 (each within the scatter of the next).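

In this assay, a hydroxy-bearing phenyl ring on the carbon with a double bond to nitrogen does not by itself lower the number: 2,4-dihydroxyphenyl in place of 1H-indol-3-yl gives a 6.9-fold higher number from compound 1 to compound 4 (0.84 log units; beyond the scatter), the opposite direction to a 29-fold lower number from compound 1 to compound 3 (1.46 log units; beyond the scatter). Replacing 4-hydroxy-3-methoxyphenyl with 2,4-dihydroxyphenyl gives a 200-fold higher number from compound 3 to compound 4 (2.30 log units; beyond the scatter), so this position separates two hydroxy-bearing phenyl rings by far more than the scatter, and the low number of compound 3 belongs to its particular ring rather than to hydroxy-bearing phenyl rings in general. Nothing available bears on why these two rings differ so sharply.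

The compounds shown do not separate the contribution of the methoxy group in compound 3 from that of the placing of the hydroxy groups, which a phenyl ring carrying only a single hydroxy group or only a single methoxy group on the same core would help to resolve. On these data alone, it also remains open how this position responds to groups of a different kind on the ring, such as an amine or a carboxylic acid.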